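The compounds below may be only part of what the source reports. "The series", "measured", "known", "first", "only" and "open" are said of these compounds alone.

In a functional assay on HCT-116 cells (Homo sapiens) for antiproliferative activity, read by MTT assay, with a stated time of 48 h (on this read-out higher numbers stand for weaker inhibition and lower numbers for stronger inhibition), compound 1 (`O=C(Nc1cc(Sc2ncn[nH]2)c(O)c2ccccc12)c1ccc([N+](=O)[O-])cc1`) reads > 100000 nM, which is a limit of the assay and not a number. Compound 3 (`O=C(Nc1cc(Sc2ncnc3nc[nH]c23)c(O)c2ccccc12)c1ccc(Cl)cc1`) reads > 100000 nM, again a limit and not a number. The series therefore gathers at the limit of > 100000 nM in this assay, at which 2 of the 3 values shown sit. For the measured compounds named here, compound 2 (`O=C(Nc1cc(Sc2ncn[nH]2)c(O)c2ccccc12)c1cccc([N+](=O)[O-])c1`), at 70200 nM, is the only true number so far. Compound 1 and compound 3 can be set against it only through their limits.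

Compound 4 (`O=C(Nc1cc(Sc2ncn[nH]2)c(O)c2ccccc12)c1ccc(Cl)cc1`) has yet to be measured. Its difference from compound 2 is 4-chlorophenyl in place of 3-nitrophenyl on a carbonyl carbon, in words 4-chlorophenyl in place of 3-nitrophenyl on a carbonyl carbon.

Just one measured step bears on this position: an at least 1.4-fold lower number from compound 1 to compound 2 (0.15 log units; that floor lies within the scatter), with 3-nitrophenyl in place of 4-nitrophenyl on a carbonyl carbon. Going by the values given here, that step exchanges one nitrophenyl for another, so no measured step covers the entry of 4-chlorophenyl. Among the compounds with values here, with compound 2 at 70200 nM as the anchor and an at least 1.4-fold lower number from compound 1 to compound 2 (0.15 log units; that floor lies within the scatter) as the only guide, no step beyond the scatter is expected in this assay. A reading at the limit remains quite possible for compound 4. The expected change is a 1.1-fold higher number from compound 2 to compound 4 (0.03 log units; within the scatter). For compound 4 the estimate is 75000 nM, with an expected range of 30000 nM to 100000 nM.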

Compound 4, half-maximal inhibitory concentration: 43300 nM
The estimate for compound 4 lay 1.7-fold (0.24 log units) above the measured number; low and high end bracket the measured number.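

In this assay, for the compounds shown here, chloro in place of nitro on an aromatic carbon gives the first step at this position that clears the scatter: an at least 2.3-fold lower number from compound 1 to compound 4 (0.36 log units; beyond the scatter). Going by these compounds alone, the comparison with the only other true number is weaker, with a 1.6-fold lower number from compound 2 to compound 4 (0.21 log units; within the scatter), so 4-chlorophenyl and 3-nitrophenyl on the carbonyl carbon cannot be told apart here. The group on the sulfur now also has a readable step, an at least 2.3-fold lower number from compound 3 to compound 4 (0.36 log units; beyond the scatter), with the group of 5 heavy atoms in compound 4 replacing the group of 9 heavy atoms in compound 3, but this step and the chloro step give floors and not full sizes because one end of each sits at a limit: the limit of > 100000 nM in this assay, at which 2 of the 4 values shown sit.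

From the compounds shown here alone, it remains open whether an amine or a carboxylic acid on the phenyl ring, or a longer alkyl chain in place of that ring on the carbonyl carbon, would move the number beyond the scatter from compound 4. Going by these compounds, the step on the sulfur is also known only with 4-chlorophenyl on the carbonyl carbon, so its size with either nitrophenyl group, and the effect of a simple methyl on the sulfur, stay unknown.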